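The source may hold more compounds than are shown below. What is called first, only, known or untested is meant among the compounds shown, and "the series" means these compounds.

Measured so far in a functional assay on HL-60 cells (Homo sapiens) for cytotoxicity, read by MTT assay; on this read-out higher numbers stand for weaker inhibition and lower numbers for stronger inhibition:

- compound 1, `Cc1ccc(S(=O)(=O)NC(C2=CC(=O)c3c(O)ccc(O)c3C2=O)C(C)C)cc1`: "not determined" (no result reported)
- compound 2, `CCOC(=O)c1ccc(S(=O)(=O)NC(C2=CC(=O)c3c(O)ccc(O)c3C2=O)C(C)C)cc1`: 150 nM
- compound 3, `Cc1ccc(S(=O)(=O)NC(C)C2=CC(=O)c3c(O)ccc(O)c3C2=O)cc1`: 30 nM

Compound 3 holds the lowest of the two numbers available. Its nearest neighbour is compound 2, whose number lies higher by a gap beyond the scatter; no single structural difference is mapped between these two, so only their values themselves can be set side by side. Compound 1 carries no number and adds nothing to the ordering.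

Compound 4, `CC(=O)c1ccc(S(=O)(=O)NC(C)C2=CC(=O)c3c(O)ccc(O)c3C2=O)cc1`, is the next entry for this assay. Against compound 3 the change is acetyl in place of methyl on an aromatic carbon. Cut one bond further out, the same change reads 4-methylphenyl to 4-acetylphenyl, the new group sitting para to a large group on the six-membered aromatic ring of carbon only.

For the measured compounds named here, no measured pair shows this change, so there is no direct step to lean on. Compound 2 gives 150 nM and differs from compound 3 in more than one place, so its value cannot be carried across. The step of a 1.5-fold higher number from compound 3 to compound 4 (0.18 log units; within the scatter) is therefore expected to be modest, leaning toward a higher number, and may well stay within the scatter. For compound 4 the expected value is 45 nM, with a range from 15 nM to 150 nM.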

Compound 4, half-maximal inhibitory concentration: 260 nM
Compound 4: the middle estimate sits 5.8-fold (0.76 log units) below what was measured, outside the stated range (above it).
By their numbers in this assay, from the lowest: compound 3; then compounds 2 and 4 (each within the scatter of the next).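

In this assay, the position para to a large group on the six-membered aromatic ring is sensitive to substitution: acetyl in place of methyl gives an 8.7-fold higher number from compound 3 to compound 4 (0.94 log units; beyond the scatter). For the compounds shown here, this is the first step that isolates a single change, since the earlier compounds allowed their values only to be set side by side. It shows that this position does not tolerate every replacement of methyl, at least on the core of compound 3, and nothing available bears on what lies behind the size of the step.

With only methyl and acetyl at this position, the compounds shown cannot separate the contribution of the carbonyl from that of the longer group, and an ethyl group, a hydroxyl, an amine or a carboxylic acid in the same place would help to tell these apart. Also open, going by these compounds, is whether the same exchange gives a step of similar size on the core of compound 1, which differs in its branched side chain and has no number that could serve as a starting point.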